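This account rests on a few compounds, and the source may have more. Where it says the series, first, only, none or still open, it means among the compounds named here.

Series notes. Compound 2 `O=C1c2ccccc2C(=O)N1CCOC(=S)N(C(=O)c1ccc(F)cc1F)c1ccc(Cl)cc1` gives 52000 nM in an ADME assay on MT4 cells (Homo sapiens) for cytotoxicity, read by MTT assay; on this read-out lower numbers stand for higher toxicity in this test and higher numbers for lower toxicity in this test. Going by the values given here, compound 3 `Cc1ccc(N(C(=O)c2ccc(F)cc2F)C(=S)OCCN2C(=O)c3ccccc3C2=O)cc1` gives 20000 nM in this assay, and the step of a 2.6-fold lower number from compound 2 to compound 3 (0.41 log units; beyond the scatter) is the only single-point change measured in the set. Compound 1 `O=C1c2ccccc2C(=O)N1CCOC(=S)N(C(=O)c1cccnc1Cl)c1ccc(Br)cc1` returns only a limit, > 100000 nM, which is the limit of > 100000 nM in this assay, at which 1 of the 3 values shown sits. Among the two numbers available, compound 2 holds the higher one, with compound 3 as the nearest at the step just quoted.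

Compound 4 `O=C1c2ccccc2C(=O)N1CCOC(=S)N(C(=O)c1ccc2ccccc2c1)c1ccc(Cl)cc1` differs from compound 2 in one place: naphthalen-2-yl in place of 2,4-difluorophenyl on a carbonyl carbon. Among the compounds with values here, no measured step touches the group on the carbonyl carbon; the single measured step alters a substituent on an aromatic carbon elsewhere and was modest. Nothing in the set therefore fixes the direction for compound 4. Within the data shown here, the expected step for compound 4 is a 1.7-fold lower number from compound 2 to compound 4 (0.24 log units; within the scatter), taken as roughly the size of the one measured change and tending toward a lower number. Compound 4 is accordingly expected to give about 30000 nM, between 10000 nM and 90000 nM.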

Compound 4, half-maximal cytotoxic concentration: 37000 nM
The estimate for compound 4 lay 1.2-fold (0.09 log units) below the measured number; the range from low to high includes it.
By their numbers in this assay, from the lowest: compounds 3, 4 and 2 (each within the scatter of the next, the first and the last beyond it). At a limit, above all of these: compound 1.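

In this assay, the group on the carbonyl carbon now has a measured change, and it is a 1.4-fold lower number from compound 2 to compound 4 (0.15 log units; within the scatter). Going by these compounds alone, exchanging 2,4-difluorophenyl for naphthalen-2-yl, which brings 2 six-membered aromatic rings of carbon only and no fluorine, therefore leaves the read-out within the scatter, whereas the only earlier step concerned a substituent on an aromatic carbon elsewhere. Nothing measured in this set gives a reason for this step.

Going by these compounds, whether the read-out stays within the scatter when the group on the carbonyl carbon carries an amine or a carboxylic acid remains open. Also open, on these data alone, is whether the naphthalen-2-yl exchange reads the same with methyl in place of chloro on the aromatic carbon, as in compound 3.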